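This account rests on a few compounds, and the source may have more. Where it says the series, first, only, none or still open, it means among the compounds named here.

Of the compounds shown here, three have been measured so far in a physicochemical assay for solubility, at pH 7.4; on this read-out higher numbers stand for higher solubility and lower numbers for lower solubility. Compound 1 `NS(=O)(=O)c1ccc(SCCCO)c(Cl)c1` gives 280 ug/mL, compound 2 `CC(=O)OCCCc1ccc(S(N)(=O)=O)cc1` gives 1600 ug/mL, and compound 3 `CC(=O)OCCCCc1ccc(S(N)(=O)=O)cc1` gives 800 ug/mL. Compound 3 thus sits within the scatter of compound 2, while the number for compound 1 lies lower than that of compound 3 by more than the scatter.

The unmeasured compound 4 `NS(=O)(=O)c1ccc(CCCCCO)cc1` differs from compound 3 at the end of the chain: hydroxymethyl in place of acetoxy on a saturated chain carbon, four bonds along the chain from an aromatic carbon. In words, this is hydroxymethyl in place of acetoxy on a saturated chain carbon, four bonds along the chain from an aromatic carbon.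

Going by the values given here, only one measured step links two compounds that differ in one place, and it bears on this change only indirectly: a 2.0-fold lower number from compound 2 to compound 3 (0.30 log units; within the scatter). That step swaps acetoxy for acetoxymethyl, so it does not show what happens when acetoxy leaves. Compound 1, at 280 ug/mL, also ends in a chain with a hydroxy group, but it differs from compound 4 in more than one place, so it only tempers the expectation slightly downward.

No change beyond the scatter is expected, and the estimated step is a 1.3-fold lower number from compound 3 to compound 4 (0.12 log units; within the scatter). For compound 4 the expected value is 600 ug/mL, with an estimated range of 250 ug/mL to 1400 ug/mL.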

Compound 4, solubility: 2600 ug/mL
The estimate for compound 4 lay 4.3-fold (0.64 log units) below the measured number; measured number above the stated range.
By their numbers in this assay, from the lowest: compound 1; then compounds 3, 2 and 4 (each within the scatter of the next, the first and the last beyond it).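

In this assay, going by these compounds alone, hydroxymethyl in place of acetoxy, on a saturated chain carbon four bonds along the chain from an aromatic carbon, gives a 3.3-fold higher number from compound 3 to compound 4 (0.51 log units; beyond the scatter) and so provides the first single-place step here that clears the scatter. Within the data shown here, the one earlier step kept the acetoxy group in the molecule, so it could not show what happens when that group leaves; this result shows that the end of the chain can shift the number by a real margin. The second comparison, 2-hydroxyethyl in place of acetoxy three bonds along the chain from an aromatic carbon, gives a 1.6-fold higher number from compound 2 to compound 4 (0.21 log units; within the scatter) and stays within the scatter, so that change shows no clear effect, and no supporting measurement explains either step.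

The compounds shown leave open whether this step reflects the arrival of the hydroxy group or only the loss of acetoxy. An amine, a carboxylic acid or a methyl ether in the same place on the chain would help separate those two readings, and a longer chain ending in hydroxy would show whether the number holds.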